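Ethyl for Methoxy on the Fused Core of Compound 2

The source may report more compounds than this note shows. Statements on the series, on what has been measured and on what is new or still open speak of the compounds shown alone.

Measured compounds:
compound 1 `Cc1ccc2c(C(=O)NCc3ccc(N4CCC(c5ccc(OC(F)(F)F)cc5)CC4)cc3)c(C)nn2c1` — > 100000 nM in an ADME assay on Vero cells (Chlorocebus sabaeus) for cytotoxicity, read by CCK-8 assay, with a stated time of 72 h; a lower number here means a stronger inhibitor, a higher number a weaker inhibitor
compound 2 `COc1ccn2nc(C)c(C(=O)NCc3ccc(N4CCC(c5ccc(OC(F)(F)F)cc5)CC4)cc3)c2c1` — > 100000 nM

Compound 2 stands only at a limit of this assay: the value > 100000 nM is a limit, not a number. Compound 1 also sits at a limit, > 100000 nM. Within the data shown here, both values share (the limit of > 100000 nM in this assay, at which 2 of the 2 values shown sit), so the only measured step, a step that the two limits leave unreadable from compound 1 to compound 2, is unreadable in size and direction.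

Compound 3 `CCc1ccn2nc(C)c(C(=O)NCc3ccc(N4CCC(c5ccc(OC(F)(F)F)cc5)CC4)cc3)c2c1` differs from compound 2 by ethyl in place of methoxy on an aromatic carbon. Among the measured compounds shown here, no measured step touches this position, and the one step that exists gives no readable size, so nothing in the numbers points to a change beyond the scatter.

Compound 3 is therefore expected to give 100000 nM, within 40000 nM to 300000 nM. That estimate means an expected step of a number no higher from compound 2 to compound 3 (the limit leaves the size open), with the result most likely again reported as a limit.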

Compound 3, half-maximal inhibitory concentration: > 100000 nM
Compound 3 gave a limit, no number; the forecaster's own chance of this, stated with the estimate: 85%; the middle value sits exactly at the limit.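

In this assay, among these compounds, compound 1, compound 2 and compound 3 all stand at one limit, so no step among them can be read in size or direction: the limit of > 100000 nM in this assay, at which 3 of the 3 values shown sit.

The compounds shown leave open how far each lies past that limit, and whether ethyl in place of methoxy on an aromatic carbon changes the value at all.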